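The source may hold more compounds than are shown below. What is called first, only, known or untested is meant among the compounds shown, and "the series" means these compounds.

Measured compounds:
compound 1, `CN1CCC[C@H]1COc1cc(O)cc(-c2ccccc2)c1`: 528 nM
compound 2, `CN1CCC[C@H]1COc1cc(O)cc(-c2ccc(O)cc2)c1`: 3.8 nM
compound 3, `CN1CCC[C@H]1COc1cc(-c2ccccc2)cc([N+](=O)[O-])c1`: 330 nM

All three were tested in an assay on membranes from Cerebral cortex for displacement of a labelled ligand from Neuronal acetylcholine receptor; alpha4/beta2 (Rattus norvegicus), with a stated time of 30 min; on this read-out higher numbers stand for weaker inhibition and lower numbers for stronger inhibition. Compound 4, `CN1CCC[C@H]1COc1cc(-c2ccc(O)cc2)cc([N+](=O)[O-])c1`, has not yet been measured there.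

Compound 1 and compound 2 share one core and differ by hydroxy in place of hydrogen on an aromatic carbon. That change gave a 140-fold lower number from compound 1 to compound 2 (2.14 log units; beyond the scatter). Compound 3 carries a different core; it differs from compound 1 by nitro in place of hydroxy on an aromatic carbon, a change that gave a 1.6-fold lower number from compound 1 to compound 3 (0.20 log units; within the scatter).

Compound 4 stands to compound 3 as compound 2 stands to compound 1: the difference is hydroxy in place of hydrogen on an aromatic carbon, the same change made on the core of compound 3, with the place described in the same words. A single earlier example is a loose guide, yet the same direction and a similarly large size are expected here. For compound 4 the expected step is a 41-fold lower number from compound 3 to compound 4 (1.62 log units; beyond the scatter). This rests on compound 2 with 3.8 nM against compound 1 with 528 nM, and on the fact that compound 1 is sat close to by compound 3 with 330 nM. On that basis compound 4 is estimated at 8 nM, plausibly between 2 nM and 40 nM.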

Compound 4, inhibition constant: 12 nM
The estimate for compound 4 lay 1.5-fold (0.18 log units) below the measured number, within the range that was stated.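

In this assay, the change from phenyl to 4-hydroxyphenyl kept its direction on the core of compound 3, giving a 28-fold lower number from compound 3 to compound 4 (1.44 log units; beyond the scatter), but it did not carry over as a fixed amount: the same change on two cores in this assay, a 140-fold lower number (2.14 log units; beyond the scatter) from compound 1 to compound 2 and a 28-fold lower number (1.44 log units; beyond the scatter) from compound 3 to compound 4, 5.1-fold (0.70 log units) apart, beyond the scatter of two such steps Nitro in place of hydroxy on an aromatic carbon also failed to carry over unchanged, since on the 4-hydroxyphenyl compounds it gave a 3.2-fold higher number from compound 2 to compound 4 (0.50 log units; beyond the scatter), which differs from the earlier step on the phenyl compounds: the same change on two cores in this assay, a 1.6-fold lower number (0.20 log units; within the scatter) from compound 1 to compound 3 and a 3.2-fold higher number (0.50 log units; beyond the scatter) from compound 2 to compound 4, 5.1-fold (0.70 log units) apart, beyond the scatter of two such steps These two pairs show that the added hydroxy gave a large step on both cores and that each step's size depended on the core, but they do not show why the sizes differ or whether either change would behave the same way on a further core.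

The compounds shown leave open whether a methoxy group, an amine or a fluorine in place of the hydroxy of the 4-hydroxyphenyl group would give a similar step. They also leave open whether a nitrile or a carboxylic acid in place of the nitro would match the values seen with nitro or with hydroxy.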